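The source may report more compounds than this note shows. Statements on the series, on what has been measured and on what is new or still open speak of the compounds shown alone.

Three compounds share one core and differ only in the aromatic ring attached to one of its carbons. Compound 1 `Oc1cccc(-c2cc(-c3ccsc3)cc(-c3ccccc3O)n2)c1` carries a thiophen-3-yl group, compound 2 `Oc1cccc(-c2cc(-c3ccco3)cc(-c3ccccc3O)n2)c1` a furan-2-yl group and compound 3 `Oc1cccc(-c2cc(-c3ccccn3)cc(-c3ccccc3O)n2)c1` a pyridin-2-yl group. In a functional assay on HCT-15 cells (Homo sapiens) for cytotoxicity, read by CCK-8 assay (on this read-out lower numbers stand for stronger inhibition and higher numbers for weaker inhibition), compound 1 gives only a limit, > 50000 nM. In this assay compound 2 likewise gives only a limit, > 50000 nM. Compound 3 also gives only a limit in this assay, > 50000 nM. For the measured compounds named here, because of the limit of > 50000 nM in this assay, at which 3 of the 3 values shown sit, no step between these three can be sized: a step that the two limits leave unreadable from compound 1 to compound 2, a step that the two limits leave unreadable from compound 1 to compound 3 and a step that the two limits leave unreadable from compound 2 to compound 3.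

Compound 4 `Oc1cccc(-c2cc(-c3cccnc3)cc(-c3ccccc3O)n2)c1` has not yet been measured. It differs from compound 3 by pyridin-3-yl in place of pyridin-2-yl on an aromatic carbon. Going by these compounds, all three measured steps bear on this change, since each swaps one aromatic ring for another on the same aromatic carbon, yet every one begins and ends at the limit, so their size stays unknown. What they do show is that three different rings there all leave the compounds at the limit. The expectation for compound 4 is therefore that the step that the limit leaves unreadable from compound 3 to compound 4 in this assay has no readable size and the value again sits at or near the limit. Compound 4 is estimated at 70000 nM, with an expected range from 20000 nM to 250000 nM.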

Compound 4, half-maximal inhibitory concentration: 8280 nM
Compound 4: middle estimate off by 8.5-fold (0.93 log units), on the high side; the whole stated range lies above it.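

In this assay, this position proves not to be indifferent to the ring it carries: pyridin-3-yl in place of pyridin-2-yl, two rings with the same atoms and the same counted donors and acceptors, gives an at least 6.0-fold lower number from compound 3 to compound 4 (0.78 log units; beyond the scatter). The pyridin-3-yl group also stands apart from the two five-membered rings, with an at least 6.0-fold lower number from compound 2 to compound 4 (0.78 log units; beyond the scatter) against furan-2-yl and an at least 6.0-fold lower number from compound 1 to compound 4 (0.78 log units; beyond the scatter) against thiophen-3-yl. Each of these sizes is only a minimum, and the steps among compound 1, compound 2 and compound 3 cannot be read, because those three sit at a limit rather than at a number: the limit of > 50000 nM in this assay, at which 3 of the 4 values shown sit.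

The compounds shown leave open whether the lower number belongs to pyridin-3-yl alone or extends to other groups on this carbon, such as pyridin-4-yl, a plain phenyl ring or an amine. They also leave open what lies behind the difference between the two pyridine rings, and how far the value of compound 4 depends on the 2-hydroxyphenyl and 3-hydroxyphenyl groups of the shared core.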